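Furan in place of thiophene on a shared nucleoside core

A few compounds are considered here, and "the series" means these few. Any claim that something is new, unique, unknown or untested is made for them only; others in the source may bear on it.

Measured compounds:
compound 1, `COc1ncnc2c1c(-c1ccoc1)cn2[C@@H]1O[C@H](CO)[C@@H](O)[C@H]1O`: 2820 nM
compound 2, `O=c1[nH]cnc2c1c(-c1cccs1)cn2[C@@H]1O[C@H](CO)[C@@H](O)[C@H]1O`: > 20000 nM

Of the compounds shown here, two have been measured in a functional assay on K562 cells (Homo sapiens), read by MTT assay, with a stated time of 72 h; a higher number here means a weaker inhibitor, a lower number a stronger inhibitor. Compound 1 gives 2820 nM. Compound 2 reaches only a limit of the assay, > 20000 nM, so no number is known for it. Compound 2 therefore stands at the limit of > 20000 nM in this assay, at which 1 of the 2 values shown sits, while compound 1 is the one of the two with a number. Compound 1 and compound 2 differ in more than one place, so their pair shows nothing beyond the two values themselves.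

Compound 3 is `O=c1[nH]cnc2c1c(-c1ccco1)cn2[C@@H]1O[C@H](CO)[C@@H](O)[C@H]1O`. It differs from compound 2 in one place: furan-2-yl in place of thiophen-2-yl on an aromatic carbon. Within the data shown here, no step between measured compounds is available, so no measured step sets a size for this change. Since compound 2 sits at > 20000 nM, and the change is a swap of one small five-membered ring for another, compound 3 is expected to give 20000 nM, with a range from 7000 nM to 60000 nM. The step this estimate means, a number no higher from compound 2 to compound 3 (the limit leaves the size open), is expected to lie within the scatter, and the assay may again report only a limit.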

Compound 3, half-maximal inhibitory concentration: 17800 nM
Compound 3: middle estimate off by 1.1-fold (0.05 log units), on the high side; the measured number falls inside the stated range.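

In this assay compound 3, which carries furan-2-yl on the aromatic carbon, gives 17800 nM, so this series now has a measured number for a five-membered ring at this position on the carbonyl-bearing core. Compound 2 gives only a limit of the assay, > 20000 nM. The exchange of thiophen-2-yl for furan-2-yl gives an at least 1.1-fold lower number from compound 2 to compound 3 (0.05 log units; that floor lies within the scatter), so the data support no claim of a real gain from the swap, and its true size cannot be read because one end of the step is not a number: the limit of > 20000 nM in this assay, at which 1 of the 3 values shown sits.

The compounds shown leave open how far compound 2 actually lies from compound 3, and whether the ring oxygen or ring sulfur matters at all at this position in this assay. They also do not show what an amine or a carboxylic acid on the five-membered ring would do, nor what a longer alkyl chain in place of furan-2-yl would do on the same core.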